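Working notes: step from compound 2 to compound 3

The source may hold more compounds than are shown below. What is called first, only, known or untested is meant among the compounds shown, and "the series" means these compounds.

Measured compounds:
- compound 1, `O=C(Nc1cccc(-n2cc(-c3ccncc3)c(-c3cc(O)cc(Cl)c3)n2)c1)Nc1ccc(Cl)c(C(F)(F)F)c1`, 57%
- compound 2, `COc1cc(Cl)cc(-c2nn(-c3cccc(NC(=O)Nc4ccc(Cl)c(C(F)(F)F)c4)c3)cc2-c2ccncc2)c1`, 53%

Two compounds have been run in a functional assay on SR cells (Homo sapiens) for inhibition, read by sulforhodamine B assay, with a stated time of 48 h, tested at 1 uM; on this read-out higher numbers stand for a weaker effect at the one concentration tested and lower numbers for a stronger effect. Compound 1 gives 57% in this assay, and compound 2 gives 53%. Within the data shown here, the single measured step, methyl in place of hydrogen on an oxygen on an aromatic ring, is a number 4 percentage points lower from compound 1 to compound 2 (within the scatter), so the two numbers are indistinguishable on this read-out and compound 2 stands alongside compound 1 rather than apart from it.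

Compound 3 is `COc1cc(Cl)cc(-c2nn(-c3cccc(NC(=O)c4cccc(C(F)(F)F)c4)c3)cc2-c2ccncc2)c1`, not yet measured in this assay. It differs from compound 2 by 3-(trifluoromethyl)phenyl in place of (4-chloro-3-(trifluoromethyl)phenyl)amino on a carbonyl carbon. Among the measured compounds shown here, neither measured step touches the carbonyl carbon or the group attached to it, so no measured step bears on this change and there is no basis in the numbers for expecting a step in either direction. The expectation for compound 3 is therefore centred on the value of compound 2, with a wide range to allow for an untested change, and the expected step is a number 7 percentage points higher from compound 2 to compound 3 (within the scatter). Compound 3 is estimated at 60%, within 35% to 90%.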

Compound 3, a percentage reported as activity, at one concentration (the size of the read-out at that concentration, not a potency): 58%
Beside the measured number, compound 3's estimate is 2 percentage points above it; the measured number falls inside the stated range.
By their numbers in this assay, from the lowest: compounds 2, 1 and 3 (each within the scatter of the next).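

In this assay, among these compounds, 3-(trifluoromethyl)phenyl in place of (4-chloro-3-(trifluoromethyl)phenyl)amino on the carbonyl carbon gives a number 5 percentage points higher from compound 2 to compound 3 (within the scatter), the only measured step at this place, and the read-out does not separate the two compounds. The swap removes the nitrogen, the chlorine and the hydrogen-bond donor of the leaving group in one step, so the series tolerates their joint loss on this read-out at the one concentration tested, while the share of each part cannot be told. No measurement at hand explains this result.

Going by these compounds, a (3-(trifluoromethyl)phenyl)amino group on the same carbonyl carbon would part the nitrogen from the chlorine, and how the read-out responds to it stays open, as does the response to a saturated amine such as piperidine in that place. On these data alone, with a single concentration behind each value in this assay, the effect of compound 1, compound 2 and compound 3 at any other concentration also stays open.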